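The source may report more compounds than this note shows. Statements on the series, on what has been measured and on what is new or still open speak of the compounds shown alone.

The measured compounds and their values in an assay on cells for displacement of a labelled ligand from adenosine receptor A3 (Homo sapiens), read by scintillation counting and radioligand binding, with a stated time of 180 min, tested at 10 uM; a higher number here means more inhibition at the concentration tested (going by the name of the read-out), a lower number less inhibition:
compound 1, `Clc1cccc(-c2nc(N3CCCCC3)c3nc[nH]c3n2)c1`, gives > 80%.
compound 2, `Oc1cccc(-c2nc(N3CCCCC3)c3nc[nH]c3n2)c1`, gives > 80%.
compound 3, `CN1CCN(c2nc(-c3cccc(Cl)c3)nc3[nH]cnc23)CC1`, gives > 80%.

Each of these values is a limit of the assay rather than a number. Compound 3 therefore stands at the limit of > 80% in this assay, at which 3 of the 3 values shown sit, with no measured size of its own to set against the others. Compound 4, `CN1CCN(c2nc(-c3cccc(O)c3)nc3[nH]cnc23)CC1`, differs from compound 3 by hydroxy in place of chloro on an aromatic carbon. The matching step from compound 1 to compound 2 is a step that the two limits leave unreadable from compound 1 to compound 2, and the step from compound 1 to compound 3 is a step that the two limits leave unreadable from compound 1 to compound 3, so neither offers a readable size. Compound 4 is thus expected to sit at the same limit, with an estimated step that the limit leaves unreadable from compound 3 to compound 4. The estimated value for compound 4 is 85%, from 70% to 100%.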

Compound 4, a percentage reported as inhibition, at one concentration (the size of the read-out at that concentration, not a potency): > 80%
Compound 4: a limit, no number; the forecaster's own chance of this, stated with the estimate: 80%; the middle value lies beyond the limit too.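

Among the compounds shown here, compound 4 also gives a limit rather than a number, so no step from compound 2 or compound 3 to compound 4 can be read: the limit of > 80% in this assay, at which 4 of the 4 values shown sit. The compounds shown leave open whether swapping chloro for hydroxy, or piperidin-1-yl for 4-methylpiperazin-1-yl, changes the inhibition at all.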